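Second chloro on a hydrazone aryl ring

The source may hold more compounds than are shown below. What is called first, only, known or untested is meant among the compounds shown, and "the series" means these compounds.

The series rests on a shared core, seen in compound 1 `Cn1nnnc1SCC(=O)N/N=C/c1ccccc1Cl`, which in a functional assay on A549 cells (Homo sapiens) for cytotoxicity, read by XTT assay, with a stated time of 24 h (a higher number here means a weaker inhibitor, a lower number a stronger inhibitor), gives compound 1 a reading of 6320000 nM. Compound 2 `Cn1nnnc1SCC(=O)N/N=C/c1cccc(Cl)c1Cl` carries one more substituent, described as chloro in place of hydrogen on an aromatic carbon, and in this assay compound 2 gives 632000 nM; the resulting step is a 10-fold lower number from compound 1 to compound 2 (1.00 log units; beyond the scatter). Compound 3 `C/C(=N\NC(=O)CSc1nnnn1C)c1ccc(Cl)cc1` is built on a different core; how the core of compound 3 differs from the core of compound 1 is not broken down here. In this assay compound 3 gives 6000000 nM, a value that lies within the usual scatter of that of compound 1.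

Compound 4 `C/C(=N\NC(=O)CSc1nnnn1C)c1ccc(Cl)cc1Cl` has not yet been measured. Relative to compound 3 it bears chloro in place of hydrogen on an aromatic carbon. This is the same kind of change that led from compound 1 to compound 2, but the surroundings of the new chloro are not the same: in compound 2 it is ortho to a chloro group and meta to a large group, while in compound 4 it is ortho to a large group and meta to a chloro group. Because a 10-fold lower number from compound 1 to compound 2 (1.00 log units; beyond the scatter) was seen on the related core, compound 4 is expected to give a lower number than compound 3, with the step estimated as a 3.0-fold lower number from compound 3 to compound 4 (0.48 log units; beyond the scatter). Tempered by the different placing of the new chloro and by the single precedent, the estimate for compound 4 in this assay is 2000000 nM, expected between 600000 nM and 6000000 nM.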

Compound 4, half-maximal inhibitory concentration: 800000 nM
Beside the measured number, compound 4's estimate is 2.5-fold (0.40 log units) above it, and the stated range covers the measured number.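

In this assay, chloro in place of hydrogen on an aromatic carbon, here ortho to a large group and meta to a chloro group, gives a 7.5-fold lower number from compound 3 to compound 4 (0.88 log units; beyond the scatter) on the core of compound 3, a step beyond the scatter. Set beside the earlier step on the core of compound 1, the change carries over with no difference in size that can be told from the scatter: the same change on two cores in this assay, a 10-fold lower number (1.00 log units; beyond the scatter) from compound 1 to compound 2 and a 7.5-fold lower number (0.88 log units; beyond the scatter) from compound 3 to compound 4, 1.3-fold (0.12 log units) apart, within the scatter of two such steps. This shows that, in these two pairs, the second chloro goes with a lower number on both cores even though the new chloro has different surroundings in each, but two pairs in a single cell assay make no general rule for the series, and they do not show why the number falls.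

The compounds shown leave open whether the step belongs to chloro itself or would also appear with a bromo, a methoxy or an amine on the same aromatic carbon. They also leave open whether a longer chain in place of the methyl on the shared ring, or a carboxylic acid on the aryl ring, would keep a step of this size.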